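The source may report more compounds than this note shows. Statements on the series, on what has been measured and on what is new or still open speak of the compounds shown alone.

Working notes on the series. The shared core carries a bromine-bearing fused bicycle and a five-membered ring with two phenyl-type substituents; both measured compounds differ only in the aryl group on the saturated ring carbon. Compound 1 `O=C1N=C(N2N=C(c3ccccc3)CC2c2ccccc2O)S/C1=C1/C(=O)Nc2ccc(Br)cc21` gives in a functional assay on cells (Cancer cell lines, Homo sapiens) for cytotoxicity, read by sulforhodamine B assay, with a stated time of 48 h (on this read-out higher numbers stand for weaker inhibition of growth and lower numbers for stronger inhibition of growth), a value of 240 nM. Compound 2 `COc1ccc(C2CC(c3ccccc3)=NN2C2=NC(=O)/C(=C3\C(=O)Nc4ccc(Br)cc43)S2)cc1` gives in this assay a value of 180 nM, and the step of a 1.3-fold lower number from compound 1 to compound 2 (0.12 log units; within the scatter) is within the scatter. Within the data shown here, compound 2 thus holds the lowest of the two numbers so far, with compound 1 its only neighbour and not separable from it.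

Compound 3 `COc1ccc(C2=NN(C3=NC(=O)/C(=C4\C(=O)Nc5ccc(Br)cc54)S3)C(c3ccc(OC)cc3)C2)cc1` is not yet measured. It differs from compound 2 by methoxy in place of hydrogen on an aromatic carbon, on the phenyl attached to the ring carbon that is double-bonded to nitrogen. Among the measured compounds shown here, no measured step touches this position; the only measured step, from compound 1 to compound 2, concerns the other aryl group and was itself within the scatter. Nothing in the series therefore points to a change beyond the scatter in this assay. For compound 3 the expected step is a 1.1-fold lower number from compound 2 to compound 3 (0.05 log units; within the scatter). Compound 3 is estimated at 160 nM, with a range from 80 nM to 320 nM.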

Compound 3, concentration for 50% growth inhibition: 200 nM
For compound 3 the middle estimate is 1.3-fold (0.10 log units) below the measured one, and the stated range covers the measured number.
By their numbers in this assay, from the lowest: compounds 2, 3 and 1 (each within the scatter of the next).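

With this step, the position on the aromatic ring that had no reading so far now has one: methoxy in place of hydrogen on an aromatic carbon, para to a large group, gives a 1.1-fold higher number from compound 2 to compound 3 (0.05 log units; within the scatter) in this assay. Together with a 1.3-fold lower number from compound 1 to compound 2 (0.12 log units; within the scatter) on the other aryl group, this means that neither of the two single changes in the series separates its pair of compounds on this read-out, so the phenyl and the 4-methoxyphenyl at this position cannot be told apart here. No measurement on hand offers a reason for this result or bears on it.

Methoxy is the only replacement for hydrogen seen at this position, so it remains open whether an amine, a carboxylic acid or a longer chain in the same place would give a step beyond the scatter. From the compounds shown here alone, it also remains open whether the same lack of separation would hold with the aryl group on the saturated ring carbon changed to something other than 2-hydroxyphenyl or 4-methoxyphenyl, or with a chlorine or a hydrogen in place of the bromine on the shared core.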